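The compounds below may be only part of what the source reports. "The series", "measured", "known", "first", "only" and "open" are said of these compounds alone.

Measured so far:
Compound 1 `CCN(CC)CCNC(=O)C1CC(C(CC)(CC)c2ccc(C#CC(C)(O)CC)c(C)c2)=CN1CC` gives 59.2%
Compound 2 `CCN(CC)CCNC(=O)C1CC=C(C(CC)(CC)c2ccc(C#CC(O)C3CCCC3)c(C)c2)N1CC` gives 47.9%
Compound 3 `CCN(CC)CCNC(=O)C1CC=C(C(CC)(CC)c2ccc(C#CC(O)C3CCCCC3)c(C)c2)N1CC` gives 45.6%

These three numbers come from an assay on isolated protein for binding affinity to vitamin D3 receptor (Homo sapiens), read by fluorescence polarization, tested at 1 uM; a higher number here means more inhibition at the concentration tested (going by the name of the read-out), a lower number less inhibition. Compound 1 stands highest of the three, with compound 2 nearest and compound 3 furthest, both of them lower than compound 1 by more than the usual scatter. For the measured compounds named here, the only one-step comparison among them is a number 2.3 percentage points lower from compound 2 to compound 3 (within the scatter), which concerns the ring on the chain next to the triple bond, not the triple bond itself.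

Compound 4 `CCN(CC)CCNC(=O)C1CC(C(CC)(CC)c2ccc(CCC(O)(CC)CC)c(C)c2)=CN1CC` differs from compound 1 in one place: a group of 8 heavy atoms (7 carbon, 1 oxygen; no ring) in place of a group of 7 heavy atoms (6 carbon, 1 oxygen; no ring), on an aromatic carbon. Going by the values given here, no measured step covers the loss of the triple bond, so the single step that exists gives little guidance here. Compound 4 is therefore expected at 50%, within a wide range from 30% to 70%, a change of a number 9.2 percentage points lower from compound 1 to compound 4 (within the scatter) that is only an estimate.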

Compound 4, a percentage reported as inhibition, at one concentration (the size of the read-out at that concentration, not a potency): 35.9%
Beside the measured number, compound 4's estimate is 14.1 percentage points above it; the range from low to high includes it.
By their numbers in this assay, from the lowest: compounds 4, 3 and 2 (each within the scatter of the next, the first and the last beyond it); then compound 1.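

Swapping the group with the triple bond for 3-ethyl-3-hydroxypentyl on this aromatic carbon gives a number 23.3 percentage points lower from compound 1 to compound 4 (beyond the scatter), so this part of the molecule can shift the read-out, which the cyclopentyl to cyclohexyl step did not show. Hydrogen-bond donor and acceptor counts are the same in both groups, so the drop does not follow those counts. No measurement here explains the drop.

This single step removes the triple bond and alters the chain together, leaving their separate contributions open. As far as these compounds go, whether an amine in place of the hydroxyl group would keep the read-out also remains open.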